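The source may report more compounds than this note shows. Statements on the series, on what has been measured and on what is new or still open speak of the compounds shown alone.

In a functional assay on NCI-H460 cells (Homo sapiens) for cytotoxicity, read by MTT assay, with a stated time of 72 h (on this read-out higher numbers stand for weaker inhibition and lower numbers for stronger inhibition), compound 3 `CC1CCN(Cc2ccc3nc(NC(=O)N/N=C/c4cn(Cc5ccccc5)c5ccccc45)sc3c2)CC1` gives 1910 nM. That number lies within the scatter of compound 2 `CC1CCN(Cc2ccc3nc(NC(=O)N/N=C/c4cn(Cc5ccccc5Cl)c5ccccc45)sc3c2)CC1`, which gives 1080 nM, while compound 1 `CCN(CC)Cc1ccc2nc(NC(=O)N/N=C/c3cn(Cc4ccc(Cl)cc4)c4ccccc34)sc2c1` gives 370 nM, a lower number than that of compound 3 and beyond the scatter. Compound 4 `CC1CCN(Cc2ccc3nc(NC(=O)N/N=C/c4cn(Cc5ccc(Cl)cc5)c5ccccc45)sc3c2)CC1` has not yet been measured. It differs from compound 3 by a single change, chloro in place of hydrogen on an aromatic carbon, para to a large group, turning benzyl into 4-chlorobenzyl. Within the data shown here, the one measured step of this kind runs the other way, a 1.8-fold higher number from compound 2 to compound 3 (0.25 log units; within the scatter), and compound 2 does not carry its chloro where compound 4 does. Compound 1, at 370 nM, already has the 4-chlorobenzyl but differs from compound 4 elsewhere, so it offers only loose support. A modest move towards a lower number is therefore expected, and it may barely clear the scatter. The expected change is a 2.2-fold lower number from compound 3 to compound 4 (0.35 log units; beyond the scatter). For compound 4 the estimated value is 850 nM, with an expected range of 350 nM to 1900 nM.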

Compound 4, half-maximal inhibitory concentration: 400 nM
Estimate against measurement, compound 4: 2.1-fold (0.33 log units) above; low and high end bracket the measured number.
By their numbers in this assay, from the lowest: compounds 1 and 4 (each within the scatter of the next); then compounds 2 and 3 (each within the scatter of the next).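

In this assay, chloro in place of hydrogen on the aromatic carbon para to a large group, turning benzyl into 4-chlorobenzyl, gives a step beyond the scatter (a 4.8-fold lower number from compound 3 to compound 4 (0.68 log units; beyond the scatter)), whereas the step that removes the chloro from the 2-chlorophenyl compound stays within it (a 1.8-fold higher number from compound 2 to compound 3 (0.25 log units; within the scatter)). The place of the chloro thus counts in this pair, as 4-chlorophenyl in place of 2-chlorophenyl also gives a step beyond the scatter (a 2.7-fold lower number from compound 2 to compound 4 (0.43 log units; beyond the scatter)). With 4-chlorobenzyl in place, 4-methylpiperidin-1-yl in place of diethylamino makes no difference beyond the scatter (a 1.1-fold higher number from compound 1 to compound 4 (0.03 log units; within the scatter)). Nothing measured here explains the effect of the chloro. As far as these compounds go, whether bromo, methoxy or a carboxylic acid on that same carbon would match the chloro remains open.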